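Swapping a silicon-bearing group for methoxymethoxy

This account rests on a few compounds, and the source may have more. Where it says the series, first, only, none or still open, it means among the compounds named here.

In a functional assay on SW480 cells (Homo sapiens) for antiproliferative activity, read by MTT assay, with a stated time of 48 h (on this read-out higher numbers stand for weaker inhibition and lower numbers for stronger inhibition), compound 3 `CC[Si](CC)(CC)C/C1=C/C[C@](C)(CCC=C(C)C)/C=C/[C@@H](OC(=O)C=C(C)C)[C@](C)(O)/C=C/C1=O` gives 2690 nM, the highest number of the three and so the weakest inhibition. Compound 1 `CC(C)=CCC[C@]1(C)/C=C/[C@@H](OC(=O)C=C(C)C)[C@](C)(O)/C=C/C(=O)/C(CN(C)C)=C\C1` gives 480 nM, and compound 2 `CCN(CC)C/C1=C/C[C@](C)(CCC=C(C)C)/C=C/[C@@H](OC(=O)C=C(C)C)[C@](C)(O)/C=C/C1=O` gives 270 nM. Compound 4 `COCOC/C1=C/C[C@](C)(CCC=C(C)C)/C=C/[C@@H](OC(=O)C=C(C)C)[C@](C)(O)/C=C/C1=O` changes one group of compound 3: a group of 4 heavy atoms (2 carbon, 2 oxygen; no ring) in place of a group of 7 heavy atoms (6 carbon, 1 silicon; no ring), on a saturated chain carbon bound to a double-bonded ring carbon. The relevant evidence comes from changes at this same place. There is a 5.6-fold higher number from compound 1 to compound 3 (0.75 log units; beyond the scatter) and a 10-fold higher number from compound 2 to compound 3 (1.00 log units; beyond the scatter), both rises that come with the silicon-bearing group, whereas a 1.8-fold lower number from compound 1 to compound 2 (0.25 log units; within the scatter) stays within the scatter. For the measured compounds named here, no measured compound carries methoxymethoxy, so a fall smaller than those rises is expected. The estimated change in this assay is a 2.7-fold lower number from compound 3 to compound 4 (0.43 log units; beyond the scatter). Compound 4 is expected at about 1000 nM, with an estimated range of 300 nM to 3300 nM.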

Compound 4, half-maximal inhibitory concentration: 3710 nM
Compound 4: middle estimate off by 3.7-fold (0.57 log units), on the low side; measured number above the stated range.
By their numbers in this assay, from the lowest: compounds 2 and 1 (each within the scatter of the next); then compounds 3 and 4 (each within the scatter of the next).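

In this assay, replacing the silicon-bearing group with methoxymethoxy leaves the number within the scatter (a 1.4-fold higher number from compound 3 to compound 4 (0.14 log units; within the scatter)), so these two groups without nitrogen cannot be told apart here. Methoxymethoxy stands well apart from both amines (a 14-fold higher number from compound 2 to compound 4 (1.14 log units; beyond the scatter); a 7.7-fold higher number from compound 1 to compound 4 (0.89 log units; beyond the scatter)), and among these four compounds, those carrying an amine at this place give the lower numbers, with none going against that pattern. No measurement shown explains this gap. The compounds shown leave open how a ring amine such as piperidine, or a plain hydroxyl, would behave at this place.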